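The source may hold more compounds than are shown below. What is called first, only, known or untested is meant among the compounds shown, and "the series" means these compounds.

Measured compounds:
compound 1, `CCCCC(=O)NC(=S)Nc1nc2cc([N+](=O)[O-])ccc2s1` — > 100000 nM
compound 2, `O=C(NC(=S)Nc1nc2cc(Br)ccc2s1)c1cccs1` — 24200 nM
compound 3, `O=C(NC(=S)Nc1nc2cc([N+](=O)[O-])ccc2s1)c1ccccc1` — 41600 nM

In a functional assay on MCF7 cells (Homo sapiens) for cytotoxicity, read by MTT assay, with a stated time of 24 h (a higher number here means a weaker inhibitor, a lower number a stronger inhibitor), compound 1 gives only a limit, > 100000 nM. Compound 2 gives 24200 nM. Compound 3 gives 41600 nM, and the gap between compound 3 and compound 2 lies within the usual scatter of the measurement, so the two cannot be told apart on these numbers. For the measured compounds named here, the one step that can be read, an at least 2.4-fold lower number from compound 1 to compound 3 (0.38 log units; beyond the scatter), rests on the limit of compound 1 and so is known only as a minimum; it concerns the group on the carbonyl carbon, as does the change to come.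

Compound 4, `O=C(NC(=S)Nc1nc2cc([N+](=O)[O-])ccc2s1)c1cccs1`, differs from compound 3 in one place: thiophen-2-yl in place of phenyl on a carbonyl carbon. Going by the values given here, no measured step covers this exchange directly. Compound 2 carries the same thiophen-2-yl group on a different core and gives 24200 nM, which sits within the scatter of compound 3, so nothing here points to a change beyond the scatter in this assay. Compound 4 is therefore expected to give about 35000 nM, with a range from 15000 nM to 80000 nM. That estimate means a step of a 1.2-fold lower number from compound 3 to compound 4 (0.08 log units; within the scatter), expected to stay within the scatter.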

Compound 4, half-maximal inhibitory concentration: 35900 nM
Beside the measured number, compound 4's estimate is 1.0-fold (0.01 log units) below it; measured number inside the range.
By their numbers in this assay, from the lowest: compounds 2, 4 and 3 (each within the scatter of the next). At a limit, above all of these: compound 1.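

For the compounds shown here, compound 4 gives the first direct reading of this exchange on the carbonyl carbon with the rest of the molecule held constant. In this assay, a 1.2-fold lower number from compound 3 to compound 4 (0.06 log units; within the scatter) shows that thiophen-2-yl and phenyl cannot be told apart here, even though a five-membered aromatic ring with a sulfur atom replaces a six-membered ring of carbon only. Compound 4 also links the other two changes: a 1.5-fold higher number from compound 2 to compound 4 (0.17 log units; within the scatter) puts nitro in place of bromo on an aromatic carbon without a separable difference, whereas an at least 2.7-fold lower number from compound 1 to compound 4 (0.44 log units; beyond the scatter) adds a second aromatic group that stands apart from butyl, a step known only as a minimum and resting on a limit: the limit of > 100000 nM in this assay, at which 1 of the 4 values shown sits.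

The compounds shown leave open how a cyclohexyl ring, or a chain shorter than butyl, would read on the carbonyl carbon, so the separation from butyl cannot yet be tied to the aromatic ring itself. Also open, going by these compounds, is whether an amine or a carboxylic acid on that aromatic carbon, in place of nitro or bromo, would give a step beyond the scatter.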